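Swapping a Thiane Arm for a Dimethylcyclohexyl Ring

The source may report more compounds than this note shows. Statements on the series, on what has been measured and on what is new or still open speak of the compounds shown alone.

The shared core ends in a chain carrying an amine, and the group on that amine varies. Compound 1 `c1ccc(CN(CCCCN(C[C@H]2Cc3ccccc3CN2)[C@H]2CCCc3cccnc32)Cc2ccccc2)cc1` carries two benzyl groups there; in a functional assay on cells for antagonist activity at C-X-C chemokine receptor type 4 (Homo sapiens), read by fluorescence and calcium flux, with stated times of 25 min and 90 s (on this read-out higher numbers stand for weaker inhibition and lower numbers for stronger inhibition), compound 1 gives > 16700 nM, which is a limit of the assay rather than a number. Compound 2 `c1ccc2c(c1)CN[C@@H](CN(CCCCNCC1CCNCC1)[C@H]1CCCc3cccnc31)C2` gives 36.5 nM, and compound 3 `c1ccc2c(c1)CN[C@@H](CN(CCCCNCC1CCSCC1)[C@H]1CCCc3cccnc31)C2` gives 69.6 nM, so that a 1.9-fold higher number from compound 2 to compound 3 (0.28 log units; within the scatter). Compound 3 thus holds the highest of the two numbers, though it sits within the scatter of compound 2. Compound 4 `CC1(C)CCC(NCCCCN(C[C@H]2Cc3ccccc3CN2)[C@H]2CCCc3cccnc32)CC1` introduces (4,4-dimethylcyclohexyl in place of (thian-4-yl)methyl on an amine nitrogen). For the measured compounds named here, no measured step tests this change directly; the one nearby step, a 1.9-fold higher number from compound 2 to compound 3 (0.28 log units; within the scatter), stayed within the scatter. A modest shift toward weaker inhibition is expected, a 2.2-fold higher number from compound 3 to compound 4 (0.33 log units; beyond the scatter). Compound 4 is estimated at 150 nM, with a range from 40 nM to 600 nM.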

Compound 4, half-maximal inhibitory concentration: 77.6 nM
The estimate for compound 4 lay 1.9-fold (0.29 log units) above the measured number; measured number inside the range.
By their numbers in this assay, from the lowest: compounds 2, 3 and 4 (each within the scatter of the next, the first and the last beyond it). At a limit, above all of these: compound 1.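

Swapping the (thian-4-yl)methyl group for the all-carbon 4,4-dimethylcyclohexyl group leaves the reading within the scatter (a 1.1-fold higher number from compound 3 to compound 4 (0.05 log units; within the scatter)), so at this amine nitrogen a ring without a hetero atom or hydrogen-bond acceptor holds the level of the thiane arm. Set against the piperidine arm, the same group gives a modest step beyond the scatter (a 2.1-fold higher number from compound 2 to compound 4 (0.33 log units; beyond the scatter)), the only such step among the three compounds with numbers. Nothing shown here gives a reason for either step.

Still open, on these data alone, is how a phenyl ring or a carboxylic acid on this amine nitrogen would read. So is whether a primary amine on the 4,4-dimethylcyclohexyl ring would recover the number of compound 2.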